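Pyridyl to oxazolyl swap on a dichlorobenzyl piperidine

The source may hold more compounds than are shown below. What is called first, only, known or untested is meant among the compounds shown, and "the series" means these compounds.

Compound 1 `Clc1cc(Cl)cc(CO[C@H]2CCCN(Cc3cccnc3)[C@H]2c2ccccc2)c1` gives 112000 nM in an assay on isolated protein for activation of cGMP-dependent protein kinase 1 (Homo sapiens), read by ADP-Glo, with stated times of 120 min and 40 min; a higher number here means that more compound is needed for the effect, a lower number that less compound is needed. Compound 2 `Clc1cc(Cl)cc(CO[C@H]2CCCN(Cc3ccncc3)[C@H]2c2ccccc2)c1` reaches only a limit of this assay, > 200000 nM. Compound 3 `Clc1cc(Cl)cc(CO[C@H]2CCCN(Cc3ccccn3)[C@H]2c2ccccc2)c1` likewise reaches only a limit, > 200000 nM. The steps of an at least 1.7-fold higher number from compound 1 to compound 3 (0.25 log units; that floor lies within the scatter) and a step that the two limits leave unreadable from compound 2 to compound 3 thus leave compound 3 parked at the limit of > 200000 nM in this assay, at which 2 of the 3 values shown sit. Compound 4 `Clc1cc(Cl)cc(CO[C@H]2CCCN(Cc3ncco3)[C@H]2c2ccccc2)c1` carries the change (1,3-oxazol-2-yl in place of pyridin-2-yl on a saturated chain carbon bound to an amine nitrogen in a ring). Among the measured compounds shown here, no measured step covers this change; the two steps that swap the pyridyl ring each raised the number only to the limit. Compound 4 is therefore expected to sit at the limit as well, with a number no higher from compound 3 to compound 4 (the limit leaves the size open) estimated as no change beyond the scatter. The estimate for compound 4 is 200000 nM, within 100000 nM to 400000 nM.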

Compound 4, half-maximal effective concentration: > 200000 nM
Compound 4: only a limit was reported; the forecaster's own chance of this, stated with the estimate: 65%; the middle value lies on the limit itself.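

Compound 4 gives only a limit in this assay, > 200000 nM. Set against the pyridin-3-yl compound, the change to 1,3-oxazol-2-yl gives an at least 1.7-fold higher number from compound 1 to compound 4 (0.25 log units; that floor lies within the scatter), while the steps to compound 4 from compound 2 and compound 3 cannot be read. A five-membered aromatic ring at this place thus joins the six-membered ones at the limit: the limit of > 200000 nM in this assay, at which 3 of the 4 values shown sit.

Where compound 2, compound 3 and compound 4 truly lie, and whether compound 1 differs from them at all, stays open. So does how a phenyl or 1,3-thiazol-2-yl ring at this place would read in this assay.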